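The source may hold more compounds than are shown below. What is called first, only, known or untested is meant among the compounds shown, and "the series" means these compounds.

In an ADME assay (liver) for metabolic stability, with Liver microsome (Homo sapiens) as the target, read by LC-MS, using microsomes, with a stated time of 30 min, tested at 4 uM (a higher number here means that more of the compound is left, a lower number that less of the compound is left), two compounds have been measured so far. Compound 1 `COCCn1c(-c2ccccc2Cl)nc2c(N3CCN(C(C)=O)CC3)nc(C)nc21` gives 35%, and compound 2 `COc1ccccc1-c1nc2c(N3CCN(C)CC3)nc(C)nc2n1C1CCOCC1` gives 22%. Compound 2 therefore stands lower of the two, and the gap between them lies beyond the usual scatter of repeated measurements. The two compounds differ in more than one place, so this gap cannot be tied to any single group.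

Compound 3 `Cc1nc(N2CCN(C)CC2)c2nc(-c3ccccc3F)n(C3CCOCC3)c2n1` has not yet been measured. Its structure departs from compound 2 in one place, on an aromatic carbon of a six-membered aromatic ring of carbon only, ortho to a large group. There, fluoro stands in place of methoxy, so 2-methoxyphenyl becomes 2-fluorophenyl (fluoro in place of methoxy on an aromatic carbon).

Among the measured compounds shown here, no measured pair shows this swap on its own, which makes any forecast rough. The starting point is compound 2 at 22%, and a moderate upward move, somewhat beyond the scatter, is expected. The estimated size of that move is a number 12 percentage points higher from compound 2 to compound 3 (beyond the scatter). With so little data, the expected range stays wide. For compound 3, the estimated value is 34%, within an expected range of 18% to 52%.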

Compound 3, percent of the compound remaining: 10%
Beside the measured number, compound 3's estimate is 24 percentage points above it; measured number below the stated range.
By their numbers in this assay, from the lowest: compound 3; then compound 2; then compound 1.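

In this assay, putting fluoro in place of methoxy, which turns 2-methoxyphenyl into 2-fluorophenyl, gives a number 12 percentage points lower from compound 2 to compound 3 (beyond the scatter). Among the compounds shown here, this is the first comparison in which only one place changes, and it shows that this aromatic carbon, ortho to a large group, is not a silent spot: a swap of one small group for another, with the rest of the molecule untouched, is enough to shift how much compound is left, and taking methoxy away does not by itself leave more of it. Nothing measured here bears on why the number falls.

Still open, on these data alone, is how a methyl group, a nitrile or a plain hydrogen on this same carbon would compare with methoxy and fluoro, and so whether the order seen here belongs to these two groups alone or forms part of a wider trend. Also open, as far as these compounds go, is whether the same swap would give a step of similar size with the other groups of compound 1 in place, since this single pair cannot support a general rule.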